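Bromo to Chloro on Two Related Spiro Cores

The compounds below may be only part of what the source reports. "The series", "measured", "known", "first", "only" and "open" are said of these compounds alone.

Compound 1 `NC1=NC2(CCSCC2)N(OCCCOc2ccccc2Br)C(N)=N1` and compound 3 `NC1=NC2(CCSCC2)N(OCCCOc2ccccc2Cl)C(N)=N1` share one core, while compound 2 `NC1=NC2(CCOCC2)N(OCCCOc2cccc(Br)c2)C(N)=N1` and compound 4 `NC1=NC2(CCOCC2)N(OCCCOc2cccc(Cl)c2)C(N)=N1` share another; how the core of compound 2 differs from that of compound 1 is not broken down here. In a functional assay on A549 cells (Homo sapiens) for antiproliferative activity, read by MTT assay, with a stated time of 72 h (a higher number here means a weaker inhibitor, a lower number a stronger inhibitor), compound 1 gives 40 nM, compound 3 gives 80 nM, and compound 2 gives 160 nM. The change chloro in place of bromo on an aromatic carbon produced a 2.0-fold higher number from compound 1 to compound 3 (0.30 log units; within the scatter). The change chloro in place of bromo on an aromatic carbon is the same kind of change, not the same, since the group sits meta to a large group rather than ortho to a large group. Compound 4 has not yet been measured in this assay. A similarly small step is expected, namely a 1.6-fold higher number from compound 2 to compound 4 (0.19 log units; within the scatter), because a 2.0-fold higher number from compound 1 to compound 3 (0.30 log units; within the scatter) stayed within the scatter. Compound 4 is therefore expected near 250 nM, between 120 nM and 550 nM.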

Compound 4, half-maximal inhibitory concentration: 150 nM
Beside the measured number, compound 4's estimate is 1.7-fold (0.22 log units) above it, within the range that was stated.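

On the second core, chloro in place of bromo gives a 1.1-fold lower number from compound 2 to compound 4 (0.03 log units; within the scatter). Set beside the earlier step, the change does not separate the two cores in this assay: the same change on two cores in this assay, a 2.0-fold higher number (0.30 log units; within the scatter) from compound 1 to compound 3 and a 1.1-fold lower number (0.03 log units; within the scatter) from compound 2 to compound 4, 2.1-fold (0.33 log units) apart, within the scatter of two such steps

So in these two pairs, the swap stays small on both cores and can be carried from one to the other without a step beyond the scatter. Two pairs are thin support for a rule, however, and they differ in where the halogen sits as well as in the core, so the effect of the core alone cannot be isolated.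

The compounds shown leave open how a group other than these two halogens, such as methoxy or an amine, would fare on the same aromatic carbon. They also leave open whether a longer chain would change these numbers.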